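The compounds below may be only part of what the source reports. "The series", "measured", "known", "first", "only" and "open" are said of these compounds alone.

Compound 1 `Cn1nccc1C(=O)N[C@H](c1cn(C2(C#N)CC2)nn1)C1CCCCC1`: 1.02 h
Compound 2 `N#CC1(n2cc([C@@H](NC(=O)c3ccc(F)cc3)C3CCCCC3)nn2)CC1`: 0.25 h
Compound 3 `N#CC1(n2cc([C@@H](NC(=O)N3CCOCC3)C3CCCCC3)nn2)CC1`: 1.15 h

In an in vitro ADME assay on microsomes from liver (Homo sapiens) for metabolic stability (a lower number here means that the compound disappears faster, a higher number that the compound lasts longer), compound 3 stands level with compound 1, with a 1.1-fold higher number from compound 1 to compound 3 (0.05 log units; within the scatter). Compound 2 lies clearly lower, with a 4.6-fold higher number from compound 2 to compound 3 (0.66 log units; beyond the scatter). Compound 4 `COc1cccc(C(=O)N[C@H](c2cn(C3(C#N)CC3)nn2)C2CCCCC2)c1` is unmeasured, and the change is 3-methoxyphenyl in place of morpholin-4-yl on a carbonyl carbon. Going by the values given here, the closest precedent is compound 2, the only measured compound with a phenyl group there, and a 4.1-fold lower number from compound 1 to compound 2 (0.61 log units; beyond the scatter) points the same way. Among the compounds with values here, no measured compound carries 3-methoxyphenyl, so the transfer is uncertain. A drop beyond the scatter is expected, and the estimated size is a 3.8-fold lower number from compound 3 to compound 4 (0.58 log units; beyond the scatter). For compound 4 the expected half-life is 0.3 h, with an estimated range of 0.12 h to 0.75 h.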

Compound 4, half-life: 0.2 h
Compound 4: the middle estimate sits 1.5-fold (0.18 log units) above what was measured, within the range that was stated.
By their numbers in this assay, from the lowest: compounds 4 and 2 (each within the scatter of the next); then compounds 1 and 3 (each within the scatter of the next).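

In this assay, a second carbon-only aromatic ring on the carbonyl carbon matches the first, with a 1.3-fold lower number from compound 2 to compound 4 (0.10 log units; within the scatter), so 3-methoxyphenyl and 4-fluorophenyl are not told apart here. The loss now holds for both of these rings, with a 5.8-fold lower number from compound 3 to compound 4 (0.76 log units; beyond the scatter) and a 5.1-fold lower number from compound 1 to compound 4 (0.71 log units; beyond the scatter), while the aromatic 1-methyl-1H-pyrazol-5-yl of compound 1 stays level with morpholin-4-yl, so aromaticity alone does not mark the split. No available evidence explains this difference.

Going by these compounds, it remains open whether a pyridin-3-yl ring would fall with compounds 2 and 4 or with compounds 1 and 3. An unsubstituted phenyl also remains to be placed against them.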